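A few compounds are considered here, and "the series" means these few. Any claim that something is new, unique, unknown or untested is made for them only; others in the source may bear on it.

Measured so far in this series:

compound 1, `CCOCn1c(Cc2cc(C)cc(C)c2)c(I)c(=O)[nH]c1=O`: 142000 nM
compound 2, `Cc1cc(C)cc(Cc2c(I)c(=O)[nH]c(=O)n2COCc2ccccc2)c1`: 98300 nM
compound 3, `CCOCn1c(Cc2ccccc2)c(Br)c(=O)[nH]c1=O`: 155000 nM

All three numbers come from an ADME assay on MT4 cells (Homo sapiens) for cytotoxicity, read by XTT assay, with a stated time of 3 days; on this read-out higher numbers stand for lower toxicity in this test and lower numbers for higher toxicity in this test. Compound 1 and compound 2 share a core and differ in one place only: phenyl in place of methyl on a saturated chain carbon bound to an oxygen on a saturated carbon. That change gave a 1.4-fold lower number from compound 1 to compound 2 (0.16 log units; within the scatter), a step that does not stand out from the run-to-run spread of this read-out. Compound 3 and compound 1 carry different cores; the difference between the two cores is not broken down here. Compound 3 sits close to compound 1, and its gap to compound 2 is likewise within the spread, so no order among the three measured compounds can be read from these values.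

Compound 4, `O=c1[nH]c(=O)n(COCc2ccccc2)c(Cc2ccccc2)c1Br`, has not yet been measured. It differs from compound 3 in one place: phenyl in place of methyl on a saturated chain carbon bound to an oxygen on a saturated carbon. Among the compounds with values here, this is the same change as the one from compound 1 to compound 2, made at the same kind of position, so the earlier pair is the only guide available. On that basis the step is expected to be small: the estimated change is a 1.3-fold lower number from compound 3 to compound 4 (0.13 log units; within the scatter), resting on the near-flat step a 1.4-fold lower number from compound 1 to compound 2 (0.16 log units; within the scatter) seen when the same group was exchanged on the other core. Compound 4 is therefore expected to give about 115000 nM in this assay, with a plausible range from 60000 nM to 230000 nM.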

Compound 4, half-maximal cytotoxic concentration: 67400 nM
The estimate for compound 4 lay 1.7-fold (0.23 log units) above the measured number; the range from low to high includes it.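

In this assay, phenyl in place of methyl on a saturated chain carbon bound to an oxygen on a saturated carbon gave a 2.3-fold lower number from compound 3 to compound 4 (0.36 log units; beyond the scatter), a modest step on the core of compound 3. Within the data shown here, the size of the step cannot be told apart between the core of compound 1 and the core of compound 3, so these data give no sign that the core alters the effect of this change: the same change on two cores in this assay, a 1.4-fold lower number (0.16 log units; within the scatter) from compound 1 to compound 2 and a 2.3-fold lower number (0.36 log units; beyond the scatter) from compound 3 to compound 4, 1.6-fold (0.20 log units) apart, within the scatter of two such steps This does not show that the change lowers the number on every core, as only the step on the core of compound 3 lies beyond the scatter, and two pairs cannot define a rule for the series or say why the step occurs.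

The compounds shown leave open how far this result holds on cores other than these two, and whether the separate differences between those cores matter. They also leave open what happens when phenyl at this place is replaced by an amine, a carboxylic acid or a longer chain, since the only exchange shown here is methyl to phenyl.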